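The source may report more compounds than this note shows. Statements on the series, on what has been measured and on what is new or still open speak of the compounds shown alone.

Working notes on the series

Two members of this series have numbers in a functional assay on cells (Cancer cell lines, Homo sapiens) for cytotoxicity, read by sulforhodamine B assay, with a stated time of 48 h (on this read-out lower numbers stand for stronger inhibition of growth and higher numbers for weaker inhibition of growth), so far. Compound 1 `COc1ccc(OC)c(-c2cc(-c3ccccc3)nn2-c2ccc(S(N)(=O)=O)cc2)c1` gives 43700 nM in this assay. Compound 2 `Oc1ccc(O)c(-c2cc(-c3ccccc3)nn2-c2ccccc2)c1` gives 75300 nM in this assay, which is the higher of the two numbers, though the gap to compound 1 is within the usual scatter of repeated measurements, so the two compounds cannot be ordered against each other on this evidence.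

Compound 3 `NS(=O)(=O)c1ccc(-n2nc(-c3ccccc3)cc2-c2cc(O)ccc2O)cc1` has not yet been measured in this assay. It differs from compound 2 in one place: sulfamoyl in place of hydrogen on an aromatic carbon, on the six-membered aromatic ring of carbon only, para to a large group. Going by the values given here, no step between measured compounds isolates this change, so its effect is not known from the series itself. Among the compounds with values here, the only guidance is that both measured compounds sit at similar, weak levels in this assay.

Compound 3 is therefore expected to stay close to compound 2, with a step of a 1.4-fold lower number from compound 2 to compound 3 (0.14 log units; within the scatter) that is expected to remain within the scatter. The estimate for compound 3 in this assay is 55000 nM, with a range from 18000 nM to 160000 nM.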

Compound 3, concentration for total growth inhibition: 98200 nM
Compound 3: middle estimate off by 1.8-fold (0.25 log units), on the low side, and the stated range covers the measured number.
By their numbers in this assay, from the lowest: compounds 1, 2 and 3 (each within the scatter of the next, the first and the last beyond it).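

In this assay, sulfamoyl in place of hydrogen on an aromatic carbon, para to a large group, gives a 1.3-fold higher number from compound 2 to compound 3 (0.12 log units; within the scatter), so with the 2,5-dihydroxyphenyl group present, this change does not separate the two compounds. With sulfamoyl held constant, 2,5-dihydroxyphenyl in place of 2,5-dimethoxyphenyl gives a 2.2-fold higher number from compound 1 to compound 3 (0.35 log units; beyond the scatter), a modest step and the only one so far that lies beyond the scatter, with compound 1 giving the lower number. No supporting measurement is available that would explain either step.

On these data alone, whether an amine or a carboxylic acid in place of the sulfamoyl would give a step beyond the scatter remains open, as does the outcome of replacing the methoxy groups with a longer alkoxy chain. As far as these compounds go, it is also open whether sulfamoyl in place of hydrogen would give a similarly small step when the 2,5-dimethoxyphenyl group is present instead of the 2,5-dihydroxyphenyl group.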